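The source may report more compounds than this note shows. Statements on the series, on what has been measured and on what is new or still open speak of the compounds shown alone.

Measured in an ADME assay on MDCKII-LE cells (Canis lupus familiaris) for permeability; a lower number here means that the compound crosses the layer more slowly, a higher number that the compound crosses the layer faster:
- compound 1 `Cc1cc2c(Oc3cnc(C(=O)N4CC(C)(C)C4)cn3)cc(C(=O)Nc3cnccn3)cc2o1`: 7.7 10^-6 cm/s
- compound 2 `COC1CN(C(=O)c2cnc(Oc3cc(C(=O)Nc4cnccn4)cc4oc(C)cc34)cn2)C1`: 21.8 10^-6 cm/s
- compound 3 `Cc1cc2c(Oc3cnc(C(=O)N4CC(C)(O)C4)cn3)cc(C(=O)Nc3cnccn3)cc2o1`: 9 10^-6 cm/s

The three compounds share a core and differ only in the group on the carbonyl carbon. Compound 3 cannot be told apart from compound 1, since a 1.2-fold higher number from compound 1 to compound 3 (0.07 log units; within the scatter) stays within the scatter. Compound 2 stands clearly above compound 3, as a 2.4-fold lower number from compound 2 to compound 3 (0.38 log units; beyond the scatter) shows.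

Compound 4 `Cc1cc2c(Oc3cnc(C(=O)N4CC5(COC5)C4)cn3)cc(C(=O)Nc3cnccn3)cc2o1` keeps the same core. Its 3-hydroxy-3-methylazetidin-1-yl group is replaced, on the same carbonyl carbon, by a group with no common name: a group of 7 heavy atoms (5 carbon, 1 nitrogen, 1 oxygen; 2 four-membered non-aromatic rings with 1 hetero atom each) in place of a group of 6 heavy atoms (4 carbon, 1 nitrogen, 1 oxygen; one four-membered non-aromatic ring with 1 hetero atom), on a carbonyl carbon.

All three measured steps bear on this change, as each swaps the group at this place. Two are modest, a 2.8-fold higher number from compound 1 to compound 2 (0.45 log units; beyond the scatter) and a 2.4-fold lower number from compound 2 to compound 3 (0.38 log units; beyond the scatter), and they run in opposite directions in terms of the number. Within the data shown here, none of the measured compounds carries a group with two four-membered rings, so no direct precedent exists, and a large move would have no support in these data. The expected change is slight and leans upward, probably without clearly leaving the scatter: a 1.4-fold higher number from compound 3 to compound 4 (0.16 log units; within the scatter).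

Compound 4 is estimated at 13 10^-6 cm/s, with an expected range from 6 10^-6 cm/s to 26 10^-6 cm/s.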

Compound 4, apparent permeability: 19.9 10^-6 cm/s
Beside the measured number, compound 4's estimate is 1.5-fold (0.18 log units) below it; the measured number falls inside the stated range.
By their numbers in this assay, from the lowest: compounds 1 and 3 (each within the scatter of the next); then compounds 4 and 2 (each within the scatter of the next).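

In this assay, the group with two four-membered rings on the carbonyl carbon gives a clear rise over the 3-hydroxy-3-methylazetidin-1-yl group, with a 2.2-fold higher number from compound 3 to compound 4 (0.34 log units; beyond the scatter), and over the 3,3-dimethylazetidin-1-yl group, with a 2.6-fold higher number from compound 1 to compound 4 (0.41 log units; beyond the scatter). It cannot be told apart from the 3-methoxyazetidin-1-yl group, with a 1.1-fold lower number from compound 2 to compound 4 (0.04 log units; within the scatter), so the position now shows an upper pair, compounds 2 and 4, and a lower pair, compounds 1 and 3, and having no hydroxy group is not enough to reach the upper pair, as compound 1 has none and stays in the lower one. Nothing measured here gives a reason for this split into two pairs.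

From the compounds shown here alone, with only four groups at this place, all of them built on a four-membered ring, it remains open whether the upper level depends on the oxygen sitting in a ring or chain rather than in a hydroxy group. A morpholine, a plain unsubstituted azetidine or a 3-aminoazetidine on the same carbonyl carbon would test how far the split between the pairs holds.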